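The source may hold more compounds than are shown below. What is called first, only, known or untested is meant among the compounds shown, and "the series" means these compounds.

Measured so far:
- compound 1, `COC(=O)c1c(O)c2ccccc2n(C)c1=O`, gives 8.3% in a functional assay, with a stated time of 20 min, tested at 0.1 mM; a lower number here means a weaker effect, a higher number a stronger effect of the compound at the concentration tested
- compound 2, `COC(=O)c1c(O)c2ccccc2n(-c2ccccc2)c1=O`, gives 9.1% in this assay
- compound 3, `Cn1c(=O)c(C(=O)NCCCCCCNC(=O)CCCCC2CCSS2)c(O)c2ccccc21`, gives 9.1% in this assay

The change from compound 1 to compound 2 is phenyl in place of methyl on an aromatic nitrogen, and it moved the read-out by a number 0.8 percentage points higher from compound 1 to compound 2 (within the scatter). Compound 3 and compound 2 stand level at the digits printed, the two highest of the three numbers, and compound 3 sits a number below compound 1 only within the scatter. How the core of compound 3 differs from the core of compound 1 is not broken down here.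

Compound 4, `O=C(CCCCC1CCSS1)NCCCCCCNC(=O)c1c(O)c2ccccc2n(-c2ccccc2)c1=O`, has not yet been measured. It differs from compound 3 by phenyl in place of methyl on an aromatic nitrogen. This is the same kind of change as from compound 1 to compound 2, though around the place the group that stands meta is a methoxycarbonyl group of 4 heavy atoms in compound 1 and a large group in compound 3. Because the earlier step was a number 0.8 percentage points higher from compound 1 to compound 2 (within the scatter), the step expected from compound 3 to compound 4 in this assay is a number 0.4 percentage points higher from compound 3 to compound 4 (within the scatter). Compound 4 is thus estimated at 9.5%, expected to lie between 3% and 17%.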

Compound 4, a percentage reported as activity, at one concentration (the size of the read-out at that concentration, not a potency): 6.2%
The estimate for compound 4 lay 3.3 percentage points above the measured number, within the range that was stated.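

In this assay, phenyl in place of methyl on an aromatic nitrogen gave a number 2.9 percentage points lower from compound 3 to compound 4 (within the scatter), and set against the earlier step, the two cores do not separate: the same change on two cores in this assay, a number 0.8 percentage points higher (within the scatter) from compound 1 to compound 2 and a number 2.9 percentage points lower (within the scatter) from compound 3 to compound 4, 3.7 percentage points apart, within the scatter of two such steps

Neither step lies beyond the scatter, so the two compounds pairs give no sign that this change acts differently on the core of compound 1 and the core of compound 3. They do not show that the change acts identically on both, however: two steps within the scatter can only fail to tell the cores apart, and a read-out at one concentration says nothing about potency.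

The compounds shown leave open whether another group on the aromatic nitrogen, such as benzyl or a longer alkyl chain, would give a step beyond the scatter on either core. Going by these compounds, it also remains open whether a carboxylic acid in place of the methoxycarbonyl group of compound 1 would alter the step.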